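Thiophen-2-yl in Place of 4-Methoxyphenyl: Estimating Growth Inhibition

The source may hold more compounds than are shown below. What is called first, only, known or untested is meant among the compounds shown, and "the series" means these compounds.

In a functional assay on KM12 cells (Homo sapiens) for inhibition, read by sulforhodamine B assay, with a stated time of 48 h (on this read-out lower numbers stand for stronger inhibition of growth and higher numbers for weaker inhibition of growth), compound 1 `COc1cc(C(=O)/C=C/c2c(-c3ccc(F)cc3)nc3ncccn23)cc(OC)c1OC` gives 1690 nM and compound 2 `COc1ccc(-c2nc3ccccn3c2/C=C/C(=O)c2cc(OC)c(OC)c(OC)c2)cc1` gives 4990 nM. Compound 2 therefore holds the higher of the two numbers, and the gap lies beyond the usual scatter. Compound 3 `COc1cc(C(=O)/C=C/c2c(-c3cccs3)nc3ccccn23)cc(OC)c1OC` has not yet been measured in this assay. It carries thiophen-2-yl in place of the 4-methoxyphenyl of compound 2, on an aromatic carbon of a five-membered aromatic ring with 2 nitrogen: thiophen-2-yl in place of 4-methoxyphenyl on an aromatic carbon. Within the data shown here, no measured pair isolates this exchange, so the expectation rests on thin evidence. Among the measured compounds shown here, the only other reference is compound 1 at 1690 nM, which differs from compound 2 in more than one place. The estimated change is a 1.7-fold lower number from compound 2 to compound 3 (0.22 log units; within the scatter), a slight shift expected to stay within the scatter. For compound 3 the expected value is 3000 nM, with an estimated range of 1000 nM to 9000 nM.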

Compound 3, concentration for 50% growth inhibition: 1320 nM
Compound 3: middle estimate off by 2.3-fold (0.36 log units), on the high side; the range from low to high includes it.
By their numbers in this assay, from the lowest: compounds 3 and 1 (each within the scatter of the next); then compound 2.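

In this assay, thiophen-2-yl in place of 4-methoxyphenyl on the aromatic carbon next to the ring nitrogen gives a 3.8-fold lower number from compound 2 to compound 3 (0.58 log units; beyond the scatter), the only step shown that isolates a single place. It shows that the number responds to the group on this carbon, and that a five-membered aromatic ring with 1 hetero atom can replace a six-membered aromatic ring of carbon only without any loss of growth inhibition. Nothing available explains this step.

This single step cannot separate the part played by the sulfur, the smaller ring and the departing methoxy group. It also leaves open how a furan-2-yl or an unsubstituted phenyl group would read on this carbon, and whether the step would carry over to the core of compound 1.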